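Bromo for Fluoro on the Sulfonyl Aryl Ring

A few compounds are considered here, and "the series" means these few. Any claim that something is new, unique, unknown or untested is made for them only; others in the source may bear on it.

Compound 2 `CN1CCN(c2ccc(C3=NN(S(=O)(=O)c4ccc(F)cc4)C(c4ccc(N(C)C)cc4)C3)cc2)CC1` carries a (4-fluorophenyl)sulfonyl group on the amine nitrogen in a ring of the shared core. In a functional assay on HCT-116 cells (Homo sapiens) for inhibition (on this read-out higher numbers stand for weaker inhibition and lower numbers for stronger inhibition), compound 2 reaches only the limit > 10000 nM rather than a number. Its neighbour compound 1 `CN1CCN(c2ccc(C3=NN(C(=O)/C=C/c4ccccc4)C(c4ccc(N(C)C)cc4)C3)cc2)CC1` bears (2-phenylethenyl)carbonyl in that position instead. In this assay compound 1 likewise stops at the limit > 10000 nM. Going by the values given here, the single measured step, a step that the two limits leave unreadable from compound 1 to compound 2, is therefore unreadable in size, since the limit of > 10000 nM in this assay, at which 2 of the 2 values shown sit, holds both values shown. Compound 3 `CN1CCN(c2ccc(C3=NN(S(=O)(=O)c4ccc(Br)cc4)C(c4ccc(N(C)C)cc4)C3)cc2)CC1` introduces (bromo in place of fluoro on an aromatic carbon). No measured step touches a halogen on this ring, so nothing shown speaks for a shift in this assay beyond the scatter. Compound 3 is accordingly expected to stay at or near the limit, with an estimated value of 15000 nM between 5000 nM and 50000 nM. The expected step that the limit leaves unreadable from compound 2 to compound 3 is judged small, with a limit most likely reported again.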

Compound 3, half-maximal inhibitory concentration: > 10000 nM
Compound 3 ended at the assay's limit; the forecaster's own chance of this, stated with the estimate: 85%; the middle value lies beyond the limit too.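

In this assay, no new step can be read among compound 1, compound 2 and compound 3, since all three stop at the same limit: the limit of > 10000 nM in this assay, at which 3 of the 3 values shown sit. The compounds shown leave open whether any group on the amine nitrogen in a ring would give a measurable value.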